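A few compounds are considered here, and "the series" means these few. Any claim that something is new, unique, unknown or untested is made for them only; others in the source may bear on it.

Measured so far:
compound 1, `CC(C)=CCC/C(C)=C/CC1Cc2c(OCCCNS(=O)(=O)c3ccc(Cl)cc3)cc(=O)n(CCCO)c2CC1(C)C`, 14.5%
compound 2, `CC(C)=CCC/C(C)=C/CC1Cc2c(OCCCNS(=O)(=O)c3ccc([N+](=O)[O-])cc3)cc(=O)n(CCCO)c2CC1(C)C`, 7.4%
compound 3, `CC(C)=CCC/C(C)=C/CC1Cc2c(OCCCOc3ccc(Cl)cc3)cc(=O)n(CCCO)c2CC1(C)C`, 25.2%

All three were tested in a functional assay on PANC-1 cells (Homo sapiens) for inhibition, read by MTT assay, with a stated time of 24 h, tested at 10 uM; on this read-out lower numbers stand for less inhibition and higher numbers for more inhibition at the one concentration tested (going by the name of the read-out). Compound 1 and compound 2 share a core and differ only in one exchange, (nitro in place of chloro on an aromatic carbon). This exchange gave a number 7.1 percentage points lower from compound 1 to compound 2 (within the scatter), so the two values cannot be told apart.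

Compound 3 carries a different linker from compound 1; the difference between the two cores is 4-chlorophenoxy in place of ((4-chlorophenyl)sulfonyl)amino on a saturated chain carbon, three bonds along the chain from an oxygen on an aromatic ring. Here the change gave a number 10.7 percentage points higher from compound 1 to compound 3 (beyond the scatter), a modest but real rise, and compound 3 stands highest of the three.

Compound 4, `CC(C)=CCC/C(C)=C/CC1Cc2c(OCCCOc3ccc([N+](=O)[O-])cc3)cc(=O)n(CCCO)c2CC1(C)C`, has not yet been measured. It is made from compound 3 by nitro in place of chloro on an aromatic carbon. The place where the exchange happens reads the same as in the move from compound 1 to compound 2, so this is the same change on the other core. On that basis the expected step is a number 7.2 percentage points lower from compound 3 to compound 4 (within the scatter), resting on a number 7.1 percentage points lower from compound 1 to compound 2 (within the scatter). Compound 4 is therefore estimated at 18%, with a likely range from 8% to 28%.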

Compound 4, a percentage reported as inhibition, at one concentration (the size of the read-out at that concentration, not a potency): 65.1%
Estimate against measurement, compound 4: 47.1 percentage points below, outside the stated range (above it).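

In this assay, the exchange of chloro for nitro gave a number 39.9 percentage points higher from compound 3 to compound 4 (beyond the scatter), and the same change behaves differently on the two cores: the same change on two cores in this assay, a number 7.1 percentage points lower (within the scatter) from compound 1 to compound 2 and a number 39.9 percentage points higher (beyond the scatter) from compound 3 to compound 4, 47 percentage points apart, beyond the scatter of two such steps. Across both differences at once, the measurement gave a number 50.6 percentage points higher from compound 1 to compound 4 (beyond the scatter), so the large rise appears only where the nitro group sits on the 4-nitrophenoxy side chain, and the step seen on the core of compound 1 did not predict the step on the core of compound 3. This shows that the change cannot simply be carried from one core to the other in this series, but with one pair on each core and a single concentration, it does not show why the cores differ or how compound 4 would behave at any other concentration.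

The compounds shown leave open whether another group in the same place on the aromatic ring, such as an amine or a carboxylic acid, would give a high or a low number. They also leave open whether a longer chain would keep the high number of compound 4.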